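The compounds below may be only part of what the source reports. "The series", "measured", "known", "first", "only" and "open" are said of these compounds alone.

Measured so far:
- compound 1, `N#Cc1cc(C(=O)N2CS(=O)(=O)c3ccccc32)cc(C2CC2)c1O`: 30%
- compound 2, `N#Cc1cc(C(=O)N2CSc3ccccc32)cc(C(F)(F)F)c1O`: 71%

The two measured compounds share a core carrying a hydroxy group and a nitrile, and were tested in an assay on cells for inhibition of solute carrier family 22 member 12 (Homo sapiens), read by scintillation counting, with a stated time of 60 min, tested at 0.1 uM; a higher number here means more inhibition at the concentration tested (going by the name of the read-out), a lower number less inhibition. Compound 1 gives 30%, which is the lower of the two numbers. Compound 2 gives 71%, a value that lies well beyond the scatter above that of compound 1; as the two structures differ in more than one place, the pair says nothing about any single change.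

The next compound, compound 3, `N#Cc1cc(C(=O)N2CS(=O)(=O)c3ccccc32)cc(Cl)c1O`, differs from compound 1 in one place only: chloro in place of cyclopropyl on an aromatic carbon. Among the measured compounds shown here, no measured pair isolates this change, so the expectation rests on the position of compound 1 alone. The account expects a small step upward, a number 10 percentage points higher from compound 1 to compound 3 (within the scatter), of a size that may not exceed the scatter. Compound 3 is therefore estimated at 40%, with a range from 15% to 65%.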

Compound 3, a percentage reported as inhibition, at one concentration (the size of the read-out at that concentration, not a potency): 29%
Beside the measured number, compound 3's estimate is 11 percentage points above it; the range from low to high includes it.
By their numbers in this assay, from the lowest: compounds 3 and 1 (each within the scatter of the next); then compound 2.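

Exchanging cyclopropyl for chloro on the aromatic carbon ortho to a hydroxy group gives a number 1 percentage points lower from compound 1 to compound 3 (within the scatter) in this assay, so this single change leaves compound 1 and compound 3 indistinguishable at the one concentration tested. Among the compounds shown here, this is the first reading at this position with everything else in the core of compound 1 held constant, and it shows that a group of 3 carbon atoms in a three-membered ring and a single chlorine atom can occupy this place with readings inside the usual scatter of each other. No measurement shown bears on what lies behind this result.

The two groups compared here are only one pair, so the compounds shown leave open whether other substituents at this position, such as an amine, a carboxylic acid or a longer alkyl chain, would leave the number level in the same way. Since the read-out is the size of inhibition at a single concentration, they also leave open whether compound 1 and compound 3 would remain indistinguishable at other concentrations.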